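This account rests on a few compounds, and the source may have more. Where it says the series, first, only, none or still open, it means among the compounds named here.

Measured compounds and their values:

Compound 1 `OC[C@@]1(c2cccc(F)c2)NC[C@@H](O)[C@@H]1O` gives 0%
Compound 2 `OC[C@]1(c2cccc(F)c2)NC[C@H](O)[C@H]1O` gives 0%
Compound 3 `COc1cccc([C@@]2(CO)NC[C@H](O)[C@H]2O)c1` gives 0%

In an assay on isolated protein for inhibition of alpha-mannosidase (Canavalia ensiformis), tested at 1000 uM (on this read-out lower numbers stand for less inhibition and higher numbers for more inhibition at the one concentration tested (going by the name of the read-out)), compound 1 stands level with compounds 2 and 3 at the digits shown; none of the three shows any measurable inhibition at the single concentration tested. The step of no change at the digits printed from compound 1 to compound 2 (within the scatter) involves no change of atoms or bonds at all, only a mirror-image arrangement, which is the content of the fact that compounds 1 and 2 differ only in the configuration as drawn. The step of no change at the digits printed from compound 2 to compound 3 (within the scatter) replaces fluoro with methoxy on an aromatic carbon, and again the read-out does not move beyond the scatter.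

Compound 4 `OC[C@@]1(c2ccccc2)NC[C@@H](O)[C@@H]1O` has not yet been measured. Compared with compound 1 the change is hydrogen in place of fluoro on an aromatic carbon. The two measured steps are the ones that bear on this: one changes configuration only, the other exchanges one group on the same aromatic ring, and neither shifts the read-out. A change that simply strips the fluoro away is a smaller alteration than either of those, so the expected step is no change at the digits printed from compound 1 to compound 4 (within the scatter), meaning no movement beyond the scatter. The estimate for compound 4 is therefore 0%, with a range from 0% to 10%.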

Compound 4, a percentage reported as inhibition, at one concentration (the size of the read-out at that concentration, not a potency): 0%
For compound 4 middle estimate and measured number coincide at the digits printed; the range from low to high includes it.
By their numbers in this assay, from the lowest: compounds 1, 2, 3 and 4 (each within the scatter of the next).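

In this assay, taking away the fluoro gives no change at the digits printed from compound 1 to compound 4 (within the scatter), so this aromatic carbon can carry plain hydrogen without the read-out leaving the level of the other compounds. The earlier step on this ring only exchanged one group for another, whereas this one shows the case with no group at all at this place, and compound 4 still gives 0%. Since compound 1 already sat at no measurable inhibition, there was nothing for the change to take away, so this step cannot show whether the fluoro matters, and nothing available here bears on why the read-out stays put.

The compounds shown leave open whether any group on this aromatic carbon can lift the read-out at all, for example an amine or a carboxylic acid, since fluoro, methoxy and hydrogen all sit at the same level. They also leave open whether a change elsewhere on the shared core, such as a longer chain in place of the hydroxymethyl group, would move the read-out where changes on this ring have not.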